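The source may report more compounds than this note shows. Statements on the series, on what has been measured and on what is new or still open speak of the compounds shown alone.

Of the compounds shown here, two sharing one core have been measured in an ADME assay on cells (Keratinocyte, Homo sapiens) for inhibition, read by fluorescence, with stated times of 2 h and 72 h; on this read-out higher numbers stand for weaker inhibition and lower numbers for stronger inhibition. Compound 1 `CC1=C2[C@H](/C=C(\C)C(=O)NCc3ccccc3F)CC[C@@H](C)[C@H]2CC1` gives 8700 nM, and compound 2 `CC1=C2[C@H](/C=C(\C)C(=O)NCc3ccc(F)cc3)CC[C@@H](C)[C@H]2CC1` gives 9600 nM. For the measured compounds named here, the only measured step is a 1.1-fold higher number from compound 1 to compound 2 (0.04 log units; within the scatter), so compound 2 cannot be told apart from compound 1 on these numbers. Compound 3 `CC1=C2[C@H](/C=C(\C)C(=O)NCCC(C)C)CC[C@@H](C)[C@H]2CC1` keeps the shared core but carries isobutyl in place of 4-fluorophenyl on a saturated chain carbon bound to an amide-type nitrogen. Going by the values given here, the measured step exchanges only 2-fluorophenyl for 4-fluorophenyl, so it bears on this change only loosely, and no measured compound lacks the aromatic ring. With compound 2 at 9600 nM as the anchor, no shift beyond the scatter is expected, although the uncertainty is wide. The estimated step is a 1.0-fold higher number from compound 2 to compound 3 (0.02 log units; within the scatter). For compound 3 the expected value is 10000 nM, with an estimated range of 4000 nM to 25000 nM.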

Compound 3, half-maximal inhibitory concentration: "not active" (no number reported)
Compound 3 has no reported number here; no gap can be computed for the estimate.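

In this assay, for the compounds shown here, compound 3 is reported as "not active" with no number, so no step from compound 2 to compound 3 can be read. Nothing shown here explains this result. The compounds shown leave open how far isobutyl in place of 4-fluorophenyl shifts the read-out.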